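Replacing a Methoxyphenyl Amide with a Dichlorophenyl Amide

The compounds below may be only part of what the source reports. "The series", "measured", "known", "first", "only" and "open" are said of these compounds alone.

Compound 1 `COc1ccccc1C(=O)Nc1c[nH]nc1C(=O)N[C@H]1CC[C@H](OC)CC1` was tested in an ADME assay on MRC5 cells (Homo sapiens) for inhibition, with a stated time of 72 h (on this read-out lower numbers stand for an effect already at smaller amounts and higher numbers for an effect only at larger amounts of compound), where compound 1 gives 1500 nM. Among the three measured compounds this is the lowest number. Compound 2 `COc1cccc(OC)c1C(=O)Nc1c[nH]nc1C(=O)N[C@H]1CC[C@H](OC)CC1` gives 31000 nM in this assay, and the step from compound 1 to compound 2, methoxy in place of hydrogen on an aromatic carbon, is large: a 21-fold higher number from compound 1 to compound 2 (1.32 log units; beyond the scatter). Compound 3 `COc1cccc(OC)c1C(=O)Nc1c[nH]nc1C(=O)NC1CCC(C)CC1` gives 45000 nM; the step with 4-methylcyclohexyl in place of 4-methoxycyclohexyl on an amide-type nitrogen is small: a 1.5-fold higher number from compound 2 to compound 3 (0.16 log units; within the scatter).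

Compound 4 `CO[C@H]1CC[C@H](NC(=O)c2n[nH]cc2NC(=O)c2cc(Cl)cc(Cl)c2)CC1` differs from compound 1 as follows: 3,5-dichlorophenyl in place of 2-methoxyphenyl on a carbonyl carbon. For the measured compounds named here, no measured step changes the aryl group in this way; the only step touching that ring, from compound 1 to compound 2, changed it by a single methoxy and still shifted the number strongly. That step shows the aryl group can matter, but it says nothing about chlorine, so the direction for compound 4 is open. The estimate for compound 4 is therefore centred close to compound 1 with a wide range, giving a 2.0-fold higher number from compound 1 to compound 4 (0.30 log units; within the scatter) as the expected step. Compound 4 is expected to give about 3000 nM, with a range from 500 nM to 30000 nM.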

Compound 4, half-maximal effective concentration: 13000 nM
Estimate against measurement, compound 4: 4.3-fold (0.64 log units) below; low and high end bracket the measured number.
By their numbers in this assay, from the lowest: compound 1; then compound 4; then compounds 2 and 3 (each within the scatter of the next).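

The dichlorophenyl ring does not restore or improve on the 2-methoxyphenyl group: in this assay, the change gives an 8.7-fold higher number from compound 1 to compound 4 (0.94 log units; beyond the scatter), so a second, quite different replacement at this carbonyl carbon also moves the effect to larger amounts of compound. Until now, the only change to this ring had been the added methoxy, a 21-fold higher number from compound 1 to compound 2 (1.32 log units; beyond the scatter); together, the two steps show that among these three rings the 2-methoxyphenyl group of compound 1 gives the lowest number, and neither step goes against this. This swap also removes the hydrogen-bond acceptor counted on the leaving group and brings in two chlorines, but no measurement shown here bears on what lies behind the higher number.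

The compounds shown leave open whether the rise follows from losing the methoxy, from adding the chlorines, or from both, as these changes occur together in one step. A plain phenyl ring, or a 3-chlorophenyl ring with a single chlorine, would help to separate these contributions on the same core.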